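The source may report more compounds than this note shows. Statements on the series, on what has been measured and on what is new or still open speak of the compounds shown alone.

Of the compounds shown here, two have been measured in a functional assay on PC-3 cells (Homo sapiens) for cytotoxicity, read by MTT assay; on this read-out lower numbers stand for stronger inhibition and higher numbers for weaker inhibition. Compound 1 `Cc1nc(Nc2ccc(Cl)c(Cl)c2)sc1C(=O)/C=C/c1ccccc1` gives 7990 nM and compound 2 `Cc1cccc(Nc2nc(C)c(C(=O)/C=C/c3ccccc3)s2)c1` gives 11700 nM. Going by the values given here, the single step so far, a 1.5-fold higher number from compound 1 to compound 2 (0.17 log units; within the scatter), concerns only the group on the nitrogen, so compound 1 and compound 2 cannot be told apart on these numbers. Compound 3 `COc1ccc(/C=C/C(=O)c2sc(Nc3ccc(Cl)c(Cl)c3)nc2C)cc1` differs from compound 1 by methoxy in place of hydrogen on an aromatic carbon. Among the compounds with values here, no measured step touches that ring, so no change beyond the scatter is expected. The expected step is a 1.1-fold lower number from compound 1 to compound 3 (0.03 log units; within the scatter). Compound 3 is estimated at 7500 nM, within 2500 nM to 22000 nM.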

Compound 3, half-maximal inhibitory concentration: > 25000 nM
Compound 3: no number, only a limit; the forecaster's own chance of this, stated with the estimate: 5%; middle value at least 3.3-fold (0.52 log units) from the limit.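

Phenyl to 4-methoxyphenyl, the first change shown at this ring, gives an at least 3.1-fold higher number from compound 1 to compound 3 (0.49 log units; beyond the scatter) in this assay, so this position is not indifferent to substitution. Compound 3 stands at > 25000 nM, which is a limit and not a number: the limit of > 25000 nM in this assay, at which 1 of the 3 values shown sits.

Still open, going by these compounds, is whether this rise belongs to methoxy itself or to any group at this place; a hydroxyl, a fluorine atom or an amine there would separate the two. Also open, on these data alone, is whether the same change on compound 2 behaves alike.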